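The source may hold more compounds than are shown below. What is called first, only, known or untested is meant among the compounds shown, and "the series" means these compounds.

Measured so far in a functional assay on BXPC-3 cells (Homo sapiens) for antiproliferative activity, read by MTT assay, with a stated time of 24 h; a higher number here means a weaker inhibitor, a lower number a stronger inhibitor: compound 1 `CCn1c(C(=O)N[C@@H](C)CO)ccc1C(CC)(CC)c1ccc(OCS(=O)(=O)c2ccccc2)c(C)c1` gives 15300 nM. Compound 2 `CCn1c(C(=O)N[C@H](CO)C(C)C)ccc1C(CC)(CC)c1ccc(OCS(=O)(=O)c2ccccc2)c(C)c1` gives 7720 nM. Compound 3 `CCn1c(C(=O)NCCC(=O)O)ccc1C(CC)(CC)c1ccc(OCS(=O)(=O)c2ccccc2)c(C)c1` gives only a limit, > 50000 nM, (the limit of > 50000 nM in this assay, at which 1 of the 3 values shown sits).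

Compound 1 holds the highest of the two numbers, yet its nearest neighbour is compound 2 and that gap is within scatter: a 2.0-fold lower number from compound 1 to compound 2 (0.30 log units; within the scatter). Compound 4 `CCn1c(C(=O)N[C@@H](CCC(=O)O)C(=O)O)ccc1C(CC)(CC)c1ccc(OCS(=O)(=O)c2ccccc2)c(C)c1` differs from compound 1 by 1,3-dicarboxypropyl in place of 1-(hydroxymethyl)ethyl on an amide-type nitrogen. The step that bears on it is the one where a 2-carboxyethyl entered, an at least 3.2-fold higher number from compound 1 to compound 3 (0.51 log units; beyond the scatter), and an at least 6.4-fold higher number from compound 2 to compound 3 (0.81 log units; beyond the scatter) runs the same way. A step to a higher number beyond the scatter is therefore expected, a 4.2-fold higher number from compound 1 to compound 4 (0.63 log units; beyond the scatter), and the assay may again report only a limit. Compound 4 is expected at 65000 nM, between 25000 nM and 170000 nM.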

Compound 4, half-maximal inhibitory concentration: > 50000 nM
Compound 4: no number, only a limit (the forecaster's own chance of this, stated with the estimate: 70%); the middle value is on the limit's open side.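

In this assay compound 4 gives > 50000 nM, which is a limit and not a number. With 1,3-dicarboxypropyl on the amide-type nitrogen, a second carboxylic acid-bearing group now stands at that limit: the limit of > 50000 nM in this assay, at which 2 of the 4 values shown sit. The series shows an at least 3.2-fold higher number from compound 1 to compound 4 (0.51 log units; beyond the scatter) and an at least 6.4-fold higher number from compound 2 to compound 4 (0.81 log units; beyond the scatter), while the step between the two carboxylic acid-bearing compounds cannot be read.

As far as these compounds go, how far above the limit either compound lies stays open, so the effect of the second carboxylic acid is unknown. Also open, from the compounds shown here alone, is whether a methyl ester, a primary amide or an amine on the same chain would stay near compound 1 and compound 2.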